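A few compounds are considered here, and "the series" means these few. Any claim that something is new, unique, unknown or untested is made for them only; others in the source may bear on it.

Measured compounds:
compound 1 `Cc1ccc(OCC(=O)N(Cc2cccs2)c2ncccn2)cc1`, giving 3700 nM in an assay on HEK293 cells for agonist activity at transient receptor potential cation channel subfamily M member 8 (Homo sapiens), read by fluorescence and calcium flux, with a stated time of 15 min; a lower number here means that less compound is needed, a higher number that more compound is needed for the effect
compound 2 `CCN(Cc1cccs1)C(=O)COc1ccc(F)cc1`, giving 422 nM in this assay

Both compounds share an amide carrying a thiophen-2-ylmethyl group on its nitrogen, and in each case an aryloxy group sits on the other side of the carbonyl. Compound 1 has the highest of the two numbers, so it is the one that needs the most material to reach the half-maximal effect; its nearest neighbour is compound 2, which gives a number clearly lower, beyond the scatter of the measurement.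

Compound 3 `Cc1ccc(OCC(=O)N(Cc2cccs2)c2c(C)n[nH]c2C)cc1` has not yet been measured. It keeps everything of compound 1 except one group on the amide-type nitrogen, where the change is 3,5-dimethyl-1H-pyrazol-4-yl in place of pyrimidin-2-yl on an amide-type nitrogen. Within the data shown here, no measured pair shows this particular change, so its effect cannot be read from a known step. Among the measured compounds shown here, the only guide is that compound 1 already sits at the weak end of the two values. In the absence of a comparable step, the expectation is a small movement in this assay, one that stays within the scatter, with the direction open. Accordingly the expected step is a 1.1-fold higher number from compound 1 to compound 3 (0.03 log units; within the scatter). For compound 3 the estimate is 4000 nM, with a range from 1000 nM to 16000 nM.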

Compound 3, half-maximal effective concentration: 0.3 nM
Beside the measured number, compound 3's estimate is 13000-fold (4.12 log units) above it; the whole stated range lies above it.
By their numbers in this assay, from the lowest: compound 3; then compound 2; then compound 1.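

In this assay, the group on the amide-type nitrogen turns out to matter enormously: 3,5-dimethyl-1H-pyrazol-4-yl in place of pyrimidin-2-yl gives a 12000-fold lower number from compound 1 to compound 3 (4.09 log units; beyond the scatter) with the rest of the molecule unchanged. The earlier compounds shown here could not show this, as they formed no pair differing in one place, so the weight of this single position was hidden until now. No measurement available here explains the size of the step, and the change alters the ring size, adds two methyl groups and brings in a hydrogen-bond donor all at once, so none of these can be singled out.

As far as these compounds go, it remains open which part of the new group carries the step, a question that a plain 1H-pyrazol-4-yl ring without the methyl groups, or a 1-methylpyrazole ring without the ring hydrogen, could help to settle. From the compounds shown here alone, it is also open how a simple phenyl ring on this nitrogen would compare, and whether the same step would hold with a fluorine in place of the methyl group on the phenoxy ring.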